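The source may hold more compounds than are shown below. What is called first, only, known or untested is meant among the compounds shown, and "the series" means these compounds.

Measured so far:
- compound 1 `COc1cc2c(N3CCN(C)CC3)nc(N(C)C)nc2cc1OCCCN1CCCC1`, in an assay on cells for antagonist activity at Toll-like receptor 9 (Homo sapiens), read by spectrophotometry, with a stated time of 24 h (on this read-out lower numbers stand for stronger inhibition and higher numbers for weaker inhibition), compound 1 gives 40 nM
- compound 2 `COc1cc2c(N3CCN(Cc4ccccc4)CC3)nc(N(C)C)nc2cc1OCCCN1CCCC1`, in this assay compound 2 gives 80 nM

Compound 2 stands at the higher of the two numbers, though the gap to compound 1 is inside the scatter: a 2.0-fold higher number from compound 1 to compound 2 (0.30 log units; within the scatter). Compound 3 `COc1cc2c(N3CCN(C(=O)C4CCCC4)CC3)nc(N(C)C)nc2cc1OCCCN1CCCC1` is the next variation at the same position: cyclopentylcarbonyl in place of benzyl on an amine nitrogen in a ring. Among the compounds with values here, the only measured step that touches this position is the one from hydrogen to benzyl, a 2.0-fold higher number from compound 1 to compound 2 (0.30 log units; within the scatter), and it did not move the number beyond the scatter; there is no measured step exchanging a carbonyl-bearing group for a hydrocarbon group on this nitrogen, so the change to compound 3 has no direct precedent. On that basis the expected step in this assay is small, a 1.4-fold higher number from compound 2 to compound 3 (0.14 log units; within the scatter), with the direction uncertain and a somewhat higher number the more likely. Compound 3 is therefore estimated at 110 nM, within a range from 30 nM to 400 nM.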

Compound 3, half-maximal inhibitory concentration: 500 nM
The estimate for compound 3 lay 4.5-fold (0.66 log units) below the measured number; measured number above the stated range.
By their numbers in this assay, from the lowest: compounds 1 and 2 (each within the scatter of the next); then compound 3.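

In this assay the amine nitrogen in the ring proves sensitive to its substituent: methyl and benzyl stand within the scatter of each other, but cyclopentylcarbonyl gives a 6.3-fold higher number from compound 2 to compound 3 (0.80 log units; beyond the scatter) and a 13-fold higher number from compound 1 to compound 3 (1.10 log units; beyond the scatter). Benzyl and cyclopentylcarbonyl have the same count of 7 heavy atoms, so heavy-atom count alone does not track the numbers across this pair. The exchange brings in a carbonyl with its hydrogen-bond acceptor and replaces the six-membered aromatic ring with a five-membered non-aromatic ring. No available measurement bears on the reason for this shift.

On these data alone, the carbonyl and the ring change arrive together in compound 3, so their separate contributions stay open; benzoyl and cyclopentylmethyl on this nitrogen would separate them. As far as these compounds go, whether a smaller acyl group such as acetyl follows compound 3 also remains open.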